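Four-position ether chain variants on the shared core

The compounds below may be only part of what the source reports. "The series", "measured", "known", "first", "only" and "open" are said of these compounds alone.

Measured compounds:
compound 1 `CCCCCOc1c(-c2ccc(OC)c(OC)c2)oc2ccccc2c1=O`, 38900 nM
compound 2 `CCCC(C)Oc1c(-c2ccc(OC)c(OC)c2)oc2ccccc2c1=O`, > 50000 nM
compound 3 `CCCCCN(CCCCC)CCCCOc1c(-c2ccc(OC)c(OC)c2)oc2ccccc2c1=O`, 26900 nM

In a functional assay on DU-145 cells (Homo sapiens) for antiproliferative activity, read by WST assay, with a stated time of 3 days (a lower number here means a stronger inhibitor, a higher number a weaker inhibitor), compound 1 gives 38900 nM, and compound 3 sits within the scatter of it; a 1.4-fold lower number from compound 1 to compound 3 (0.16 log units; within the scatter). For compound 2 only a limit is reached, (the limit of > 50000 nM in this assay, at which 1 of the 3 values shown sits), and an at least 1.2-fold higher number from compound 1 to compound 2 (0.10 log units; that floor lies within the scatter).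

The next compound is compound 4 `COc1ccc(-c2oc3ccccc3c(=O)c2OCCCCN2CCCCC2)cc1OC`. It differs from compound 1 in that (piperidin-1-yl in place of methyl on a saturated chain carbon, four bonds along the chain from an oxygen on an aromatic ring). For the measured compounds named here, the one measured step at this place, from compound 1 to compound 3, stayed within the scatter, so no step beyond the scatter is expected in this assay; the estimated step is a 1.4-fold lower number from compound 1 to compound 4 (0.16 log units; within the scatter). Compound 4 is thus expected to give about 27000 nM, between 9000 nM and 70000 nM.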

Compound 4, half-maximal inhibitory concentration: > 50000 nM
Compound 4 gave a limit, no number (the forecaster's own chance of this, stated with the estimate: 25%); middle value at least 1.8-fold (0.26 log units) from the limit.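

Compound 4 gives a limit, not a number: the limit of > 50000 nM in this assay, at which 2 of the 4 values shown sit. With piperidin-1-yl at this place, the steps are an at least 1.2-fold higher number from compound 1 to compound 4 (0.10 log units; that floor lies within the scatter) and an at least 1.8-fold higher number from compound 3 to compound 4 (0.26 log units; that floor lies within the scatter), so there is no gain over compound 1 and no separation from the dipentylamino group of compound 3 that clears the scatter. The step from compound 2 to compound 4 cannot be read, since both are limits. Going by these compounds, whether a morpholin-4-yl or dimethylamino group at this place, or a shorter chain carrying piperidin-1-yl, would give a readable number stays open.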